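Dropping the chloro: compound 1 to compound 3

The compounds below may be only part of what the source reports. "The series", "measured", "known", "first", "only" and "open" are said of these compounds alone.

Compounds measured so far:
- compound 1, `COc1cc(/C=C/C(=O)c2cccc(-n3cc(-c4ccc(Cl)cc4)[nH]c3=O)c2)cc(OC)c1OC`, 2460 nM
- compound 2, `O=C(/C=C/c1cccc(O)c1)c1cccc(-n2cc(-c3ccc(Cl)cc3)[nH]c2=O)c1`, 13700 nM

Both compounds were tested in a functional assay on HCC 2998 cells (Homo sapiens) for inhibition; on this read-out lower numbers stand for stronger inhibition of growth and higher numbers for weaker inhibition of growth. Of the two numbers, compound 1 gives the lower one; the number for compound 2 is the higher, and the gap between them lies beyond the usual scatter of this assay. Compound 1 is therefore the starting point for the next step.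

Compound 3, `COc1cc(/C=C/C(=O)c2cccc(-n3cc(-c4ccccc4)[nH]c3=O)c2)cc(OC)c1OC`, has not yet been measured. It differs from compound 1 in one place only: hydrogen in place of chloro on an aromatic carbon. For the measured compounds named here, no pair of measured compounds separated by a single change of this kind is available, so the size of the step cannot be read from the data. A modest loss is expected, with the number for compound 3 rising somewhat against compound 1, though possibly within the scatter; the expected step is a 1.8-fold higher number from compound 1 to compound 3 (0.26 log units; within the scatter). Compound 3 is estimated at 4500 nM, between 1500 nM and 13000 nM.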

Compound 3, concentration for 50% growth inhibition: 1260 nM
Compound 3: middle estimate off by 3.6-fold (0.55 log units), on the high side; the measured number lies below the stated range.
By their numbers in this assay, from the lowest: compounds 3 and 1 (each within the scatter of the next); then compound 2.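

In this assay, putting hydrogen in place of chloro gives a 2.0-fold lower number from compound 1 to compound 3 (0.29 log units; within the scatter), so this first single-place comparison in the series stays within the usual scatter of the assay. At this position, para to a large group, the change from 4-chlorophenyl to phenyl therefore leaves inhibition of growth at a level that repeated measurements could not tell apart from that of compound 1, and the chloro is not required to hold it there. No measurement at hand accounts for this outcome.

On these data alone, whether an amine or a carboxylic acid on this same aromatic carbon would shift the number beyond the scatter remains open. Also open, as far as these compounds go, is whether the same exchange of chloro for hydrogen in compound 2 would give a step of similar size.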